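A few compounds are considered here, and "the series" means these few. Any claim that something is new, unique, unknown or untested is made for them only; others in the source may bear on it.

Measured in an ADME assay on microsomes from liver (Homo sapiens) for metabolic stability; a lower number here means slower removal, a higher number faster removal of the compound:
Compound 1 `CC(C)Oc1cc(Oc2ccc(S(C)(=O)=O)cc2)cc(-c2cccc(=O)[nH]2)c1`: < 8 mL/min/kg (a limit)
Compound 2 `CC(C)Oc1cc(Oc2ccc(S(C)(=O)=O)cc2)cc(-c2nccc(=O)[nH]2)c1`: < 9.8 mL/min/kg (a limit)

Compound 2 is known only as a limit, < 9.8 mL/min/kg, so it has no exact place in this assay. Compound 1 is likewise known only as a limit, < 8 mL/min/kg. Among the measured compounds shown here, the one measured step is a step that the two limits leave unreadable from compound 1 to compound 2, and it supplies no size to carry forward. For the measured compounds named here, no measured step involves a chloro group.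

Compound 3 `CC(C)Oc1cc(Oc2ccc(S(C)(=O)=O)cc2)cc(-c2ncc(Cl)c(=O)[nH]2)c1` is still to be measured. It differs from compound 2 as follows: chloro in place of hydrogen on an aromatic carbon. This is chloro in place of hydrogen on an aromatic carbon, para to a large group.

With no measured size to draw on, the expected step is a step that the limit leaves unreadable from compound 2 to compound 3, with no direction expected beyond the scatter. For compound 3 the estimated clearance is 8 mL/min/kg, with an expected range from 4 mL/min/kg to 16 mL/min/kg.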

Compound 3, clearance: < 8 mL/min/kg
Compound 3: no number, only a limit; the forecaster's own chance of this, stated with the estimate: 60%; the middle value sits exactly at the limit.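

In this assay compound 3 is known only as a limit, < 8 mL/min/kg. The steps to compound 3 from compound 1 and from compound 2 cannot be read. Left open is the actual clearance of all three compounds, and whether chloro in place of hydrogen on an aromatic carbon changes it at all.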